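A few compounds are considered here, and "the series" means these few. Any claim that something is new, unique, unknown or untested is made for them only; others in the source may bear on it.

Measured so far, in a functional assay on the whole organism (Tail, strain ICR) with Mus musculus as the target, in the tail flick test, with a stated time of 150 min, at a dose of 25 umol/kg by the oral route; on this read-out lower numbers stand for a weaker effect and higher numbers for a stronger effect at the one dose given: compound 1 `O=C(CN(c1nc(Cl)nc2[nH]cnc12)C1CC1)N[C@@H](CO)C(=O)OCc1ccccc1` gives 27.9%; compound 2 `N=C(N)NCCC[C@H](NC(=O)CN(c1nc(Cl)nc2[nH]cnc12)C1CC1)C(=O)OCc1ccccc1` gives 6.12%; compound 3 `NCCCC[C@H](NC(=O)CN(c1nc(Cl)nc2[nH]cnc12)C1CC1)C(=O)OCc1ccccc1` gives 9.88%.

Compound 3 stands second highest of the three numbers in this assay. Its nearest neighbour is compound 2, whose value lies within the scatter of it, as the step of a number 3.8 percentage points higher from compound 2 to compound 3 (within the scatter) shows; the furthest is compound 1, from which the step of a number 18 percentage points lower from compound 1 to compound 3 (beyond the scatter) is beyond the scatter.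

Compound 4 `CC(C)C[C@H](NC(=O)CN(c1nc(Cl)nc2[nH]cnc12)C1CC1)C(=O)OCc1ccccc1` is not yet measured. It differs from compound 3 in one place: isopropyl in place of 3-aminopropyl on a saturated chain carbon, two bonds along the chain from an amide-type nitrogen and a carbonyl carbon

Within the data shown here, two measured steps touch the same place. The step of a number 18 percentage points lower from compound 1 to compound 3 (beyond the scatter) and the step of a number 21.8 percentage points lower from compound 1 to compound 2 (beyond the scatter) both lowered the number when the hydroxy of compound 1 was replaced. Among the measured compounds shown here, compound 4 removes the 3-aminopropyl again, but puts in isopropyl, which none of the measured compounds carries, so the direction is uncertain. A modest rise toward compound 1 is expected, with wide bounds, amounting to the estimated step of a number 8.1 percentage points higher from compound 3 to compound 4 (within the scatter). Compound 4 is therefore expected to give about 18%, within the estimated range 5% to 35%.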

Compound 4, a percentage reported as activity, at one dose (the size of the read-out at that dose, not a potency): 5.26%
Compound 4: middle estimate off by 12.7 percentage points, on the high side; measured number inside the range.
By their numbers in this assay, from the lowest: compounds 4, 2 and 3 (each within the scatter of the next); then compound 1.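

In this assay, the all-carbon isopropyl of compound 4 cannot be told apart from the nitrogen-bearing groups, with a number 4.6 percentage points lower from compound 3 to compound 4 (within the scatter) and a number 0.9 percentage points lower from compound 2 to compound 4 (within the scatter) as the two readings. Put in place of hydroxy on this saturated chain carbon, isopropyl gives a number 22.6 percentage points lower from compound 1 to compound 4 (beyond the scatter) and so joins the two earlier replacements, which shows that the fall from compound 1 does not depend on a nitrogen in the new group. Compound 1, the only one carrying hydroxy, now stands apart from all three others, and none of them goes against this.

The compounds shown leave open whether a carboxylic acid or a longer hydroxyalkyl chain at this place would stand with compound 1 or with the other three. Nothing given here speaks to the reason for these steps.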